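Replacing oxan-4-yl with methoxymethyl on the carbonyl carbon

This account rests on a few compounds, and the source may have more. Where it says the series, first, only, none or still open, it means among the compounds named here.

In a functional assay on COR-L23 cells (Homo sapiens) for antiproliferative activity, read by CellTiter-Glo, with a stated time of 4 days (a higher number here means a weaker inhibitor, a lower number a stronger inhibitor), compound 1 (`CCC(=O)NCc1ccc(NC(=O)[C@H]2C[C@@H]2c2cccnc2)cc1`) reads > 2500 nM and this is a limit of the assay, not a number. Compound 2 (`C[C@H](NC(=O)CC(F)(F)F)c1ccc(NC(=O)[C@H]2C[C@@H]2c2cccnc2)cc1`) gives 18 nM in this assay and compound 3 (`C[C@H](NC(=O)C1CCOCC1)c1ccc(NC(=O)[C@H]2C[C@@H]2c2cccnc2)cc1`) gives 7 nM as the lower of the two actual numbers. Compound 4 (`COCC(=O)N[C@@H](C)c1ccc(NC(=O)[C@H]2C[C@@H]2c2cccnc2)cc1`) has methoxymethyl in place of oxan-4-yl on a carbonyl carbon. Among the measured compounds shown here, one measured step bears on this change: a 2.6-fold lower number from compound 2 to compound 3 (0.41 log units; beyond the scatter) is the only exchange at this place, and it is modest. Like the group of compound 2, methoxymethyl has no ring, so a modest move back towards a higher number is expected, although this rests on a single pair. The estimated step is a 2.1-fold higher number from compound 3 to compound 4 (0.33 log units; beyond the scatter) in this assay as a working expectation. Compound 4 is expected to read about 15 nM with an estimated range of 5 nM to 45 nM in this series.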

Compound 4, half-maximal inhibitory concentration: 111 nM
Compound 4: middle estimate off by 7.4-fold (0.87 log units), on the low side; the whole stated range lies below it.
By their numbers in this assay, from the lowest: compound 3; then compound 2; then compound 4. At a limit, above all of these: compound 1.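

In this assay, among the compounds shown here, the change on the carbonyl carbon is worth far more than the only earlier exchange here suggested: a 16-fold higher number from compound 3 to compound 4 (1.20 log units; beyond the scatter). Methoxymethyl also trails 2,2,2-trifluoroethyl, another group with no ring, with a 6.2-fold higher number from compound 2 to compound 4 (0.79 log units; beyond the scatter), so the absence of a ring does not alone set the number at this place. The remaining step, an at least 22-fold lower number from compound 1 to compound 4 (1.35 log units; beyond the scatter), is only a bound, as compound 1 sits at a limit of the assay: the limit of > 2500 nM in this assay, at which 1 of the 4 values shown sits.

From the compounds shown here alone, whether the low number of compound 3 follows from the ring of oxan-4-yl or from its larger count of heavy atoms stays open, and cyclohexyl or a longer chain such as 2-methoxyethyl would help to separate the two. Going by these compounds, how an amine such as piperidin-4-yl would read on this carbonyl carbon also remains open.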